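Chloro for Amino on Two Fused Cores

This account rests on a few compounds, and the source may have more. Where it says the series, first, only, none or still open, it means among the compounds named here.

Compound 1, `Nc1ncnc2c1ncn2C[C@@H]1C[C@H](O)c2ccccc21`: in an ADME assay on L1210/0 cells (Mus musculus) for cytotoxicity, with a stated time of 48 h (on this read-out higher numbers stand for weaker inhibition and lower numbers for stronger inhibition), compound 1 gives only the limit > 200000 nM.
Compound 2, `O[C@H]1C[C@@H](Cn2cnc3c(Cl)ncnc32)c2ccccc21`: in this assay compound 2 likewise gives only the limit > 200000 nM.
Compound 3, `Nc1ncnc2c1ncn2[C@@H]1C[C@@H]2COC[C@H]2[C@H]1CO`: in this assay compound 3 also gives only the limit > 200000 nM.

Compound 1 and compound 2 share one core and differ by chloro in place of amino on an aromatic carbon. The step between them, a step that the two limits leave unreadable from compound 1 to compound 2, cannot be sized, since both compounds stop at a limit. Compound 3 carries a different core; how the two cores differ is not broken down here. Compound 4, `OC[C@@H]1[C@@H]2COC[C@H]2C[C@H]1n1cnc2c(Cl)ncnc21`, has not yet been measured; it differs from compound 3 by chloro in place of amino on an aromatic carbon, the same change as that from compound 1 to compound 2.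

Among the compounds with values here, every value in hand sits at the same point, as the limit of > 200000 nM in this assay, at which 3 of the 3 values shown sit, shows, so no measured step gives a direction. The step from compound 3 to compound 4 is therefore expected to be a number no higher from compound 3 to compound 4 (the limit leaves the size open), a guess that rests only on compound 1 and compound 2 both giving limits. On that basis compound 4 is estimated to reach about 200000 nM, most likely again reported only as a limit.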

Compound 4, half-maximal inhibitory concentration: > 200000 nM
Compound 4: no number, only a limit; the forecaster's own chance of this, stated with the estimate: 80%; the middle value lies on the limit itself.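

In this assay compound 4 gives > 200000 nM as a limit and not a number. Within the data shown here, compound 3 also stops at a limit, so no step between compound 3 and compound 4 can be read. The compounds shown leave open whether chloro in place of amino changes this read-out on either core, since every result is the same limit: the limit of > 200000 nM in this assay, at which 4 of the 4 values shown sit.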